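The compounds below may be only part of what the source reports. "The series", "measured", "known", "first", "only" and "open" are said of these compounds alone.

Measured compounds and their values:
compound 1 `S=C(SCc1nc2ccccc2[nH]1)N1CCOCC1` — 1890 nM
compound 2 `CN(C)C(=S)SCc1nc2ccccc2[nH]1` — 2120 nM
compound 3 `CCCNC(=S)SCc1nc2ccccc2[nH]1` — 2290 nM

In a functional assay on the whole organism for inhibition, with Cicer arietinum as the target, with a stated time of 7 days (on this read-out lower numbers stand for stronger inhibition and higher numbers for weaker inhibition), compound 3 holds the highest of the three numbers, yet the steps of a 1.2-fold higher number from compound 1 to compound 3 (0.08 log units; within the scatter) and a 1.1-fold higher number from compound 2 to compound 3 (0.03 log units; within the scatter) both fall within the scatter, so no order among the three can be read.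

Compound 4 `CCCCNC(=S)SCc1nc2ccccc2[nH]1` differs from compound 3 by methyl in place of hydrogen on a saturated chain carbon, three bonds along the chain from an amide-type nitrogen. Going by the values given here, no measured step alters chain length. The measured steps of a 1.1-fold higher number from compound 1 to compound 2 (0.05 log units; within the scatter), a 1.2-fold higher number from compound 1 to compound 3 (0.08 log units; within the scatter) and a 1.1-fold higher number from compound 2 to compound 3 (0.03 log units; within the scatter) each exchange the whole group on the thiocarbonyl carbon and all stay within the scatter, so the amine side appears tolerant across these three compounds. In this assay no step beyond the scatter is therefore expected for the butyl extension. Compound 4 is expected to give 2300 nM, range 1200 nM to 4500 nM. The expected step is a 1.0-fold higher number from compound 3 to compound 4 (0.00 log units; within the scatter).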

Compound 4, half-maximal inhibitory concentration: 2110 nM
For compound 4 the middle estimate is 1.1-fold (0.04 log units) above the measured one; measured number inside the range.
By their numbers in this assay, from the lowest: compounds 1, 4, 2 and 3 (each within the scatter of the next).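

In this assay the propyl to butyl extension gives a 1.1-fold lower number from compound 3 to compound 4 (0.04 log units; within the scatter), the first direct read on chain length in the series: methyl in place of hydrogen on this saturated chain carbon, three bonds along the chain from an amide-type nitrogen, produces no step beyond the scatter. Butylamino also stays level with the other two amine groups, with a 1.0-fold lower number from compound 2 to compound 4 (0.00 log units; within the scatter) and a 1.1-fold higher number from compound 1 to compound 4 (0.05 log units; within the scatter) as the steps. No available evidence accounts for this flat picture.

Going by these compounds, whether an octyl chain or a branched tert-butyl group on the nitrogen would stay within the scatter remains open. Changes to the shared core also remain open.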